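This account rests on a few compounds, and the source may have more. Where it says the series, first, only, none or still open, it means among the compounds named here.

Measured so far in a functional assay on the whole organism (strain Swiss) with Mus musculus as the target, in the maximal electroshock model, with a stated time of 0.25 h, at a dose of 300 mg/kg by the intraperitoneal route; on this read-out lower numbers stand for a weaker effect and higher numbers for a stronger effect at the one dose given:

compound 1, `CCC(C(=O)N1CCN(c2cccc(F)c2)CC1)N1C(=O)CCC1=O` — 75%
compound 2, `CCC(C(=O)N1CCN(c2ccc(F)cc2)CC1)N1C(=O)CCC1=O` — 0%
compound 3, `CC(C(=O)N1CCN(c2ccc(F)cc2)CC1)N1C(=O)CCC1=O` — 100%

Compound 4, `CC(C(=O)N1CCN(c2cccc(F)c2)CC1)N1C(=O)CCC1=O`, has not been tested in this assay. Its core is that of compound 3, which differs from the core of compound 2 by hydrogen in place of methyl on a saturated chain carbon, two bonds along the chain from an amide-type nitrogen in a ring and a carbonyl carbon. Compound 4 differs from compound 3 by 3-fluorophenyl in place of 4-fluorophenyl on an amine nitrogen in a ring. The same change, (3-fluorophenyl in place of 4-fluorophenyl on an amine nitrogen in a ring), is seen between two measured compounds, where it gave a number 75 percentage points higher from compound 2 to compound 1 (beyond the scatter); the surroundings of the change are the same in both pairs, so it is the same change. A smaller step is expected this time, a number 5 percentage points lower from compound 3 to compound 4 (within the scatter), because compound 3 already gives 100%, the top of what this assay can report, leaving no room for a rise. For compound 4 the expected value is 95%.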

Compound 4, a percentage reported as activity, at one dose (the size of the read-out at that dose, not a potency): 100%
Compound 4: middle estimate off by 5 percentage points, on the low side; the range from low to high includes it.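

Swapping 4-fluorophenyl for 3-fluorophenyl gives no change at the digits printed from compound 3 to compound 4 (within the scatter), so the step seen on the other core does not carry over in size: the same change on two cores in this assay, a number 75 percentage points higher (beyond the scatter) from compound 2 to compound 1 and no change at the digits printed (within the scatter) from compound 3 to compound 4, 75 percentage points apart, beyond the scatter of two such steps Hydrogen in place of methyl still gives a number 25 percentage points higher from compound 1 to compound 4 (beyond the scatter), but this step also differs in size between the two pairs: the same change on two cores in this assay, a number 100 percentage points higher (beyond the scatter) from compound 2 to compound 3 and a number 25 percentage points higher (beyond the scatter) from compound 1 to compound 4, 75 percentage points apart, beyond the scatter of two such steps This does not show that the two fluorophenyl groups are equivalent on the core of compound 3, as a single dose cannot separate two compounds at the top of what the read-out can report.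

The compounds shown leave open how a chlorophenyl or an unsubstituted phenyl group would behave on these cores. They also leave open what a longer chain on the saturated carbon would do.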